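Swapping the aryl group on a fused six-ring core

The compounds below may be only part of what the source reports. "The series", "measured", "known", "first", "only" and "open" are said of these compounds alone.

Measured compounds:
- compound 1, `Cc1nc2c3ccccc3ccc2c2nc3c(ccc4ccccc43)c(-c3cccc([N+](=O)[O-])c3)c12`: 50700 nM
- compound 2, `COc1ccc(-c2c3ccc4ccccc4c3nc3c2c(C)nc2c4ccccc4ccc32)cc1`: 45900 nM

Both compounds were tested in a functional assay on HeLa cells (Homo sapiens) for cytotoxicity, read by MTT assay, with a stated time of 48 h; on this read-out lower numbers stand for stronger inhibition and higher numbers for weaker inhibition. Compound 1 gives 50700 nM and compound 2 gives 45900 nM; the two numbers sit within the usual scatter of each other, so neither compound can be called the more potent one. Among the compounds with values here, the only measured step, a 1.1-fold lower number from compound 1 to compound 2 (0.04 log units; within the scatter), exchanges one aryl group for another on the shared core and leaves the read-out essentially unchanged.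

Compound 3, `Cc1nc2c3ccccc3ccc2c2nc3c(ccc4ccccc43)c(-c3cccc4ccccc34)c12`, has not yet been measured. It differs from compound 2 in one place: naphthalen-1-yl in place of 4-methoxyphenyl on an aromatic carbon. Within the data shown here, this is again an exchange of one aryl group for another at the same position, and the single measured step of that kind, a 1.1-fold lower number from compound 1 to compound 2 (0.04 log units; within the scatter), stayed within the scatter. On that basis no step beyond the scatter is expected in this assay for compound 3, in either direction. Compound 3 is therefore estimated at 46000 nM, with a range from 20000 nM to 110000 nM, which corresponds to an expected step of a 1.0-fold higher number from compound 2 to compound 3 (0.00 log units; within the scatter).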

Compound 3, half-maximal inhibitory concentration: 14900 nM
Compound 3: the middle estimate sits 3.1-fold (0.49 log units) above what was measured, outside the stated range (below it).
By their numbers in this assay, from the lowest: compound 3; then compounds 2 and 1 (each within the scatter of the next).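

In this assay this position turns out to respond to the aryl group it carries. In place of 4-methoxyphenyl, naphthalen-1-yl gives a 3.1-fold lower number from compound 2 to compound 3 (0.49 log units; beyond the scatter) and in place of 3-nitrophenyl it gives a 3.4-fold lower number from compound 1 to compound 3 (0.53 log units; beyond the scatter) and both steps are modest but beyond the scatter, so the earlier exchange between two substituted phenyl groups did not show the full reach of this position. Nothing measured on these compounds explains why naphthalen-1-yl stands apart, although the counted change from 4-methoxyphenyl is clear: two six-membered aromatic rings of carbon only replace one, and the single hydrogen-bond acceptor is gone.

The three compounds cannot separate the effect of the second ring from the loss of the methoxy or nitro group, and a comparison with unsubstituted phenyl or naphthalen-2-yl at the same carbon would help to pull these apart. On these data alone, it also remains open how this position would take a group of a different kind, such as an amine, a carboxylic acid or a saturated ring like morpholine, and whether any gain seen in these cells would extend to other cell lines.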